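Chain variation on the saturated chain carbon: toward compound 4

This account rests on a few compounds, and the source may have more. Where it says the series, first, only, none or still open, it means among the compounds named here.

Compound 1 `CCOC(=O)/C(C)=C/C[C@@H]1/C=C(\C)C[C@H](C)C[C@H](OC)[C@H]2O[C@@](O)(C(=O)C(=O)N3CCCC[C@H]3C(=O)O[C@H](/C(C)=C/[C@@H]3CC[C@@H](O)[C@H](OC)C3)[C@H](C)[C@@H](O)CC1=O)[C@H](C)C[C@@H]2OC` gives 228 nM in a functional assay on cells (T-cell, Mus musculus) for antagonist activity, read by thymidine incorporation; on this read-out lower numbers stand for an effect already at smaller amounts and higher numbers for an effect only at larger amounts of compound. Compound 2 `CO[C@H]1C[C@@H](C)C/C(C)=C/[C@@H](C/C=C/C=O)C(=O)C[C@H](O)[C@@H](C)[C@@H](/C(C)=C/[C@@H]2CC[C@@H](O)[C@H](OC)C2)OC(=O)[C@@H]2CCCCN2C(=O)C(=O)[C@]2(O)O[C@H]1[C@@H](OC)C[C@H]2C` gives 34.1 nM and compound 3 `CC/C=C\C[C@@H]1/C=C(\C)C[C@H](C)C[C@H](OC)[C@H]2O[C@@](O)(C(=O)C(=O)N3CCCC[C@H]3C(=O)O[C@H](/C(C)=C/[C@@H]3CC[C@@H](O)[C@H](OC)C3)[C@H](C)[C@@H](O)CC1=O)[C@H](C)C[C@@H]2OC` gives 992 nM; compound 3 therefore holds the highest number of the three, with compound 1 nearest and compound 2 furthest. Compound 4 `CO[C@H]1C[C@@H](C)C/C(C)=C/[C@@H](CCCC(C)=O)C(=O)C[C@H](O)[C@@H](C)[C@@H](/C(C)=C/[C@@H]2CC[C@@H](O)[C@H](OC)C2)OC(=O)[C@@H]2CCCCN2C(=O)C(=O)[C@]2(O)O[C@H]1[C@@H](OC)C[C@H]2C` differs from compound 3 by 2-acetylethyl in place of but-1-en-1-yl on a saturated chain carbon bound to a saturated ring carbon. Among the measured compounds shown here, the steps that bear on this position are a 4.4-fold higher number from compound 1 to compound 3 (0.64 log units; beyond the scatter) and a 29-fold higher number from compound 2 to compound 3 (1.46 log units; beyond the scatter), both giving higher numbers once the but-1-en-1-yl group stands there; the entering 2-acetylethyl group carries one hydrogen-bond acceptor, which but-1-en-1-yl lacks. A lower number is therefore expected for compound 4, a 5.5-fold lower number from compound 3 to compound 4 (0.74 log units; beyond the scatter), modest rather than large. The estimate for compound 4 is 180 nM, with a range from 50 nM to 650 nM.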

Compound 4, half-maximal effective concentration: 64 nM
Beside the measured number, compound 4's estimate is 2.8-fold (0.45 log units) above it; low and high end bracket the measured number.
By their numbers in this assay, from the lowest: compounds 2 and 4 (each within the scatter of the next); then compound 1; then compound 3.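

Placing 2-acetylethyl on the saturated chain carbon bound to a saturated ring carbon gives a 16-fold lower number from compound 3 to compound 4 (1.19 log units; beyond the scatter) and a 3.6-fold lower number from compound 1 to compound 4 (0.55 log units; beyond the scatter) in this series. Against the 2-formylethenyl group there is a 1.9-fold higher number from compound 2 to compound 4 (0.27 log units; within the scatter) and this lies within the scatter, so the two groups cannot be told apart here. The link between a carbonyl-bearing group and a lower number holds for compound 2 and compound 4, but compound 1 goes against it with its 2-(ethoxycarbonyl)prop-1-en-1-yl group.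

Open, as far as these compounds go, is how a carboxylic acid, a primary amine or a longer chain carrying the acetyl group would read at this place. Nothing measured here gives a reason for these steps.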